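Notes on the ring-nitrogen aryl group in this series

The source may report more compounds than this note shows. Statements on the series, on what has been measured and on what is new or still open speak of the compounds shown alone.

Measured so far:
compound 1, `Nc1scc(CN2CCN(c3ccc(Cl)cc3Cl)CC2)c1C(=O)c1ccc(Cl)cc1`: 0%
compound 2, `Nc1scc(CN2CCN(c3ccc(Cl)cc3F)CC2)c1C(=O)c1ccc(Cl)cc1`: 0%
compound 3, `Nc1scc(CN2CCN(c3ccccc3C(F)(F)F)CC2)c1C(=O)c1ccc(Cl)cc1`: 0%

In an assay on CHO cells for displacement of a labelled ligand from adenosine receptor A1 (Homo sapiens), read by scintillation counting, with a stated time of 120 min, tested at 10 uM (a lower number here means less inhibition, a higher number more inhibition at the concentration tested (going by the name of the read-out)), compound 1 gives 0%, compound 2 gives 0% and compound 3 gives 0%. Compound 2 therefore stands level with compounds 1 and 3 at the digits recorded; none of the three shows inhibition beyond the scatter in this assay.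

The measured steps all concern the aryl group on the amine nitrogen of the ring: no change at the digits printed from compound 1 to compound 2 (within the scatter); no change at the digits printed from compound 1 to compound 3 (within the scatter); no change at the digits printed from compound 2 to compound 3 (within the scatter). Each of these exchanges one halogenated or trifluoromethyl-bearing phenyl for another and none moves the read-out.

Compound 4, `Nc1scc(CN2CCN(c3ccncc3)CC2)c1C(=O)c1ccc(Cl)cc1`, has not been measured. Its change from compound 2 is pyridin-4-yl in place of 4-chloro-2-fluorophenyl on an amine nitrogen in a ring. For the measured compounds named here, this is a different kind of exchange from the three measured ones, since a ring with one hetero atom and one hydrogen-bond acceptor enters where a carbon-only ring left, so no measured step covers it directly. Still, with every variation of this group so far sitting at the same flat level, the expected step of a number 3 percentage points higher from compound 2 to compound 4 (within the scatter) is no change beyond the scatter. Compound 4 is estimated at 3% in this assay, within 0% to 15%.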

Compound 4, a percentage reported as inhibition, at one concentration (the size of the read-out at that concentration, not a potency): 1%
Compound 4: the middle estimate sits 2 percentage points above what was measured; low and high end bracket the measured number.
By their numbers in this assay, from the lowest: compounds 1, 2, 3 and 4 (each within the scatter of the next).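

In this assay the aryl group on the amine nitrogen in the ring stays at the same flat level even when the kind of ring changes, with the steps reading a number 1 percentage points higher from compound 2 to compound 4 (within the scatter) and a number 1 percentage points higher from compound 3 to compound 4 (within the scatter) and a number 1 percentage points higher from compound 1 to compound 4 (within the scatter) for the three exchanges to pyridin-4-yl. The flat level at this position is therefore not confined to halogenated or trifluoromethyl-bearing phenyl groups, since a six-membered aromatic ring with a hetero atom and a hydrogen-bond acceptor, smaller in heavy atoms than 4-chloro-2-fluorophenyl, sits there as well. No measurement at hand gives a reason for this flat level.

From the compounds shown here alone, with all four compounds this close to nothing, it stays open whether any group at this position can raise inhibition at all, and a benzyl group, an acetyl group or a carboxylic acid-bearing chain on that nitrogen could read differently. Going by these compounds, since the shared core is constant throughout, the part played by its free amine and its 4-chlorophenyl ketone also stays open.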